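The source may report more compounds than this note shows. Statements on the series, on what has been measured and on what is new or still open speak of the compounds shown alone.

Measured so far:

Compound 1, `COc1n[nH]c2ncc(NC(=O)c3c(F)ccc(/N=N\c4ccccc4)c3F)cc12`, gives in an unclassified assay for pharmacokinetics, read by NMR, tested at 2 mg/mL (a lower number here means that the compound disappears faster, a higher number that the compound lasts longer), a limit of the assay: > 10 h.
Compound 2, `COc1n[nH]c2ncc(NC(=O)c3c(F)ccc(/N=N\c4ccccc4F)c3F)cc12`, gives in this assay a limit of the assay: > 20 h.
Compound 3, `COc1n[nH]c2ncc(NC(=O)c3c(F)ccc(/N=N\c4ccccc4C)c3F)cc12`, gives in this assay a limit of the assay: > 70 h.

Compound 1 therefore stands only at a limit in this assay, and the two other values are limits as well. The steps between the measured compounds cannot be read as sizes: a step that the two limits leave unreadable from compound 1 to compound 2, a step that the two limits leave unreadable from compound 1 to compound 3 and a step that the two limits leave unreadable from compound 2 to compound 3 all fall between two limits. What the three compounds share is that none disappeared before its limit was reached.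

Compound 4, `COc1ccccc1/N=N\c1ccc(F)c(C(=O)Nc2cnc3[nH]nc(OC)c3c2)c1F`, differs from compound 1 in one place: methoxy in place of hydrogen on an aromatic carbon. For the measured compounds named here, no measured step has a methoxy entering here, so the measured steps bear on it only in that every neighbour of compound 1 remained at a limit in this assay. The step from compound 1 to compound 4 is therefore expected to be small or not readable, a step that the limit leaves unreadable from compound 1 to compound 4, with a long half-life again. Compound 4 is estimated at 40 h in this assay, within a range from 10 h to 150 h, and most likely reported only as a limit.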

Compound 4, half-life: > 24 h
Compound 4: no number, only a limit; the forecaster's own chance of this, stated with the estimate: 80%; the middle value lies beyond the limit too.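

For the compounds shown here, compound 4 stands only at a limit in this assay, as do compound 1, compound 2 and compound 3, and no step from any of them to compound 4 can be read as a size. The compounds shown leave open how long any of the four actually lasts, and whether hydrogen, fluoro, methyl or methoxy at this place changes the half-life at all.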